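Bromo in place of chloro: compound 3 against compound 2

The compounds below may be only part of what the source reports. "The series", "measured", "known", "first", "only" and "open" are said of these compounds alone.

compound 1 `CCCCNc1nnc(COc2ccc(-c3ccccc3)cc2)s1`: 27.3%
compound 2 `Clc1ccc(Nc2nnc(COc3ccc(-c4ccccc4)cc3)s2)cc1`: 52.3%

In a functional assay on the whole organism (strain Wistar) for inhibition, with Rattus norvegicus as the target, read by paw edema, with a stated time of 3 h, at a dose of 10 mg/kg by the oral route (on this read-out lower numbers stand for less inhibition and higher numbers for more inhibition at the one dose given (going by the name of the read-out)), compound 2 stands highest of the two numbers. Going by the values given here, the one measured step is a number 25 percentage points higher from compound 1 to compound 2 (beyond the scatter), a swap of the whole group on the ring nitrogen, not a swap within a halogen set.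

Compound 3 `Brc1ccc(Nc2nnc(COc3ccc(-c4ccccc4)cc3)s2)cc1` differs from compound 2 by bromo in place of chloro on an aromatic carbon. Among the compounds with values here, no measured step exchanges one halogen for another, so that step gives no direct guide, and no step beyond the scatter is expected. The estimated step is a number 0.3 percentage points lower from compound 2 to compound 3 (within the scatter). Compound 3 is expected to give 52% in this assay, between 36% and 68%.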

Compound 3, a percentage reported as inhibition, in the whole organism at one dose (the size of the read-out at that dose, not a potency): 63.6%
Estimate against measurement, compound 3: 11.6 percentage points below, and the stated range covers the measured number.
By their numbers in this assay, from the lowest: compound 1; then compound 2; then compound 3.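

At this place, on an aromatic carbon para to a large group, the exchange of one halogen for another is not neutral: in this assay, bromo in place of chloro gives a number 11.3 percentage points higher from compound 2 to compound 3 (beyond the scatter) on the same core. With 4-bromophenyl in place of butyl, the result is a number 36.3 percentage points higher from compound 1 to compound 3 (beyond the scatter), so the gain over butyl depends on which halogen the phenyl group carries. Nothing available explains the difference between bromo and chloro.

As far as these compounds go, whether iodo or fluoro would extend or reverse this halogen difference remains open. So does the outcome with a methoxy group or a carboxylic acid at this place.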